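From methylamino to piperidin-1-yl on a shared core

The source may report more compounds than this note shows. Statements on the series, on what has been measured and on what is new or still open speak of the compounds shown alone.

For the measured compounds named here, in an ADME assay on GM00637 cells (Homo sapiens) for cytotoxicity, read by MTT assay, with a stated time of 72 h (on this read-out lower numbers stand for stronger inhibition and higher numbers for weaker inhibition), compound 1 `CNc1cc2nc(-c3ccccc3)nn(-c3ccccc3)c-2cc1=O` gives 930 nM, the lower of the two numbers measured so far, and compound 2 `CCN(CC)c1cc2nc(-c3ccccc3)nn(-c3ccccc3)c-2cc1=O` gives 2730 nM. Compound 3 `O=c1cc2n(-c3ccccc3)nc(-c3ccccc3)nc-2cc1N1CCCCC1` is still unmeasured and keeps the core of compound 1, with one change: piperidin-1-yl in place of methylamino on an aromatic carbon. Going by the values given here, the only measured step that bears on this is a 2.9-fold higher number from compound 1 to compound 2 (0.47 log units; beyond the scatter), where diethylamino replaced methylamino. A single step is a thin guide, but a rise of similar size is expected in this assay. The expected step is a 2.6-fold higher number from compound 1 to compound 3 (0.41 log units; beyond the scatter). For compound 3 the estimated value is 2400 nM, within a range of 1000 nM to 6000 nM.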

Compound 3, half-maximal inhibitory concentration: 1190 nM
Compound 3: the middle estimate sits 2.0-fold (0.30 log units) above what was measured, and the stated range covers the measured number.
By their numbers in this assay, from the lowest: compounds 1 and 3 (each within the scatter of the next); then compound 2.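

Swapping methylamino for piperidin-1-yl leaves the number within the scatter (a 1.3-fold higher number from compound 1 to compound 3 (0.11 log units; within the scatter)), even though piperidin-1-yl is larger and has no hydrogen-bond donor. Piperidin-1-yl also gives a lower number than the open-chain diethylamino (a 2.3-fold lower number from compound 2 to compound 3 (0.36 log units; beyond the scatter)), so the rise seen with diethylamino does not hold for every larger group at this position. Nothing shown here explains this difference between the ring and the open chain. On these data alone, whether a smaller ring such as pyrrolidin-1-yl, or morpholin-4-yl with its ring oxygen, would behave like piperidin-1-yl remains open.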